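The compounds below may be only part of what the source reports. "The series", "measured", "known", "first", "only" and "open" are said of these compounds alone.

In a functional assay on K562 cells (Homo sapiens) for antiproliferative activity, read by MTT assay, with a stated time of 5 days (a lower number here means a stronger inhibitor, a higher number a weaker inhibitor), compound 1 `COc1ccc(C=C(C(=O)c2cc(OC)c(OC)c(OC)c2)c2ccccc2)cc1[N+](=O)[O-]` gives > 10000000 nM, which is a limit of the assay and not a number. Within the data shown here, compound 2 `COc1ccc(C=C(C(=O)c2cc(OC)c(OC)c(OC)c2)c2ccc(C)cc2)cc1[N+](=O)[O-]` gives 2430000 nM, the higher of the two real numbers so far, while compound 3 `COc1ccc(/C=C(/C(=O)c2cc(OC)c(OC)c(OC)c2)c2ccccc2)cc1` gives 20000 nM, a far smaller number and a gap well beyond the scatter. Among the measured compounds shown here, the only measured step is an at least 4.1-fold lower number from compound 1 to compound 2 (0.61 log units; beyond the scatter), in which methyl replaces hydrogen on an aromatic carbon. Compound 4 `COc1cc(C(=O)C(=Cc2ccccc2)c2ccc(C)cc2)cc(OC)c1OC` keeps that methyl and differs elsewhere, with phenyl in place of 4-methoxy-3-nitrophenyl on a double-bonded chain carbon bound to a double-bonded chain carbon. For the measured compounds named here, no measured step makes this swap, so the methyl step offers little guidance on its size. The closest hint is compound 3, which also lacks the 4-methoxy-3-nitrophenyl group and gives 20000 nM. A clear move towards stronger inhibition is therefore expected, but with wide uncertainty: the expected change is a 16-fold lower number from compound 2 to compound 4 (1.21 log units; beyond the scatter). For compound 4 the estimated value is 150000 nM, with an expected range of 15000 nM to 2000000 nM.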

Compound 4, half-maximal inhibitory concentration: 2970000 nM
Compound 4: middle estimate off by 20-fold (1.30 log units), on the low side; the measured number lies above the stated range.
By their numbers in this assay, from the lowest: compound 3; then compounds 2 and 4 (each within the scatter of the next). At a limit, above all of these: compound 1.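

In this assay, swapping the 4-methoxy-3-nitrophenyl group for plain phenyl on this double-bonded chain carbon gives no difference that can be read: a 1.2-fold higher number from compound 2 to compound 4 (0.09 log units; within the scatter). Among these compounds, no earlier step touched this place, and it now appears that, with the methyl kept, these two groups cannot be told apart here, even though phenyl enters with fewer heavy atoms and no hydrogen-bond acceptors. Both compounds give real numbers, but they should be read against the upper end of the assay: the limit of > 10000000 nM in this assay, at which 1 of the 4 values shown sits.

The compounds shown leave open whether the same swap would give a similar result in a compound without the methyl. They also leave open whether a phenyl ring carrying an amine or a carboxylic acid would read differently at this place.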